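The compounds below may be only part of what the source reports. "The series", "measured", "known", "first", "only" and "open" are said of these compounds alone.

In a functional assay on A549 cells (Homo sapiens) for cytotoxicity, read by MTT assay, with a stated time of 48 h (on this read-out higher numbers stand for weaker inhibition and lower numbers for stronger inhibition), compound 1 `O=C(/C=C/c1cccc(F)c1)Nc1ccc(CC2=CC(=O)OC2)cc1` gives > 50000 nM as its reading, which is a limit of the assay and not a number. Compound 2 `O=C(/C=C/c1ccccc1F)Nc1ccc(CC2=CC(=O)OC2)cc1` holds the higher of the two actual numbers at 40000 nM and compound 3 `C=C1OC(=O)C=C1Cc1ccc(NC(=O)/C=C/c2ccccc2F)cc1` sits lower at 7410 nM.

Compound 4 `O=C(/C=C/c1ccc(F)cc1)Nc1ccc(CC2=CC(=O)OC2)cc1` is still unmeasured and differs from compound 2 by a single swap: 4-fluorophenyl in place of 2-fluorophenyl on a double-bonded chain carbon bound to a double-bonded chain carbon. Going by the values given here, the closest precedent is an at least 1.2-fold lower number from compound 1 to compound 2 (0.09 log units; that floor lies within the scatter), also a swap of one fluorophenyl group for another at the same place. The other measured step, a 5.4-fold lower number from compound 2 to compound 3 (0.73 log units; beyond the scatter), changes a different group and says little here. No step beyond the scatter is therefore expected in this assay, and the direction is open. The estimated value for compound 4 is 45000 nM, with an expected range of 22000 nM to 90000 nM. This estimate means an expected 1.1-fold higher number from compound 2 to compound 4 (0.05 log units; within the scatter).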

Compound 4, half-maximal inhibitory concentration: 41800 nM
Compound 4: middle estimate off by 1.1-fold (0.03 log units), on the high side; low and high end bracket the measured number.
By their numbers in this assay, from the lowest: compound 3; then compounds 2 and 4 (each within the scatter of the next). At a limit, above all of these: compound 1.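

Swapping 2-fluorophenyl for 4-fluorophenyl gives a 1.0-fold higher number from compound 2 to compound 4 (0.02 log units; within the scatter) in this assay, the first comparison at this place between two actual numbers, and it does not separate the two groups. Swapping 3-fluorophenyl for 4-fluorophenyl gives an at least 1.1-fold lower number from compound 1 to compound 4 (0.07 log units; that floor lies within the scatter), which is only a floor. Compound 1 stands at a limit of the assay: the limit of > 50000 nM in this assay, at which 1 of the 4 values shown sits.

Still open, going by these compounds, is whether an amine or a carboxylic acid in place of the fluorine would move the number at all. Also open, on these data alone, is how 4-fluorophenyl would read on the core of compound 3.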